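This account rests on a few compounds, and the source may have more. Where it says the series, first, only, none or still open, it means among the compounds named here.

Working notes on the series. Compound 1 `O=[N+]([O-])c1cc(C(F)(F)F)cc([N+](=O)[O-])c1Oc1c(Cl)cc(Cl)cc1/C=N\OCc1ccccc1` is the reference; compound 2 `O=[N+]([O-])c1cc(C(F)(F)F)cc([N+](=O)[O-])c1Oc1c(Cl)cc(Cl)cc1/C=N\OCc1ccccc1F` differs from it by fluoro in place of hydrogen on an aromatic carbon. In a functional assay on HepG2 cells (Homo sapiens) for antiproliferative activity, read by MTT assay, with a stated time of 48 h (a lower number here means a stronger inhibitor, a higher number a weaker inhibitor), compound 1 gives 1120 nM and compound 2 gives 820 nM, a step of a 1.4-fold lower number from compound 1 to compound 2 (0.14 log units; within the scatter). Compound 3 `O=[N+]([O-])c1cc(C(F)(F)F)cc([N+](=O)[O-])c1Oc1c(Br)cc(Br)cc1/C=N\OCc1ccccc1` carries a different core; the difference between the core of compound 1 and the core of compound 3 is not broken down here. In this assay compound 3 gives 1480 nM, a number within the scatter of those of compound 1 and compound 2. Compound 4 `O=[N+]([O-])c1cc(C(F)(F)F)cc([N+](=O)[O-])c1Oc1c(Br)cc(Br)cc1/C=N\OCc1ccccc1F` stands to compound 3 as compound 2 stands to compound 1, differing by fluoro in place of hydrogen on an aromatic carbon, the same change at the same kind of place. The earlier step was a 1.4-fold lower number from compound 1 to compound 2 (0.14 log units; within the scatter). A step of about that size is expected next, a 1.4-fold lower number from compound 3 to compound 4 (0.15 log units; within the scatter). Compound 4 is therefore estimated at 1050 nM in this assay, expected between 600 nM and 1900 nM.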

Compound 4, half-maximal inhibitory concentration: 1100 nM
Compound 4: middle estimate off by 1.0-fold (0.02 log units), on the low side, and the stated range covers the measured number.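

In this assay, benzyl to 2-fluorobenzyl gives a 1.3-fold lower number from compound 3 to compound 4 (0.13 log units; within the scatter) on the core of compound 3. Set beside the earlier step, the change carries across these two cores with no difference that can be read: the same change on two cores in this assay, a 1.4-fold lower number (0.14 log units; within the scatter) from compound 1 to compound 2 and a 1.3-fold lower number (0.13 log units; within the scatter) from compound 3 to compound 4, 1.0-fold (0.01 log units) apart, within the scatter of two such steps. Each step lies within the scatter on its own, so this agreement does not show that the change alters activity on either core, and two cores do not establish transfer across the series.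

The compounds shown leave open whether a chloro or methoxy group, or an amine, at this same place would give a step beyond the scatter. Also open, as far as these compounds go, is whether fluoro elsewhere on this ring would behave alike on both cores.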